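The source may report more compounds than this note shows. Statements on the series, on what has been measured and on what is new or still open speak of the compounds shown alone.

Series built on the shared core of compound 1 `Cn1cc(-c2n[nH]c3ccc(N)cc23)cn1`, which in an assay on isolated protein for inhibition of tyrosine-protein kinase receptor UFO (Homo sapiens), with a stated time of 1.5 h (a lower number here means a stronger inhibitor, a higher number a weaker inhibitor), gives compound 1 a value of 8910 nM. Compound 2 `Cn1cc(-c2n[nH]c3ccc(Nc4ccccc4)cc23)cn1` carries a phenyl on the ring nitrogen that bears hydrogen in compound 1; in this assay compound 2 gives 580 nM. Going by the values given here, the one step so far, a 15-fold lower number from compound 1 to compound 2 (1.19 log units; beyond the scatter), is the only comparison in the set. Compound 2 therefore stands with the lowest of the two numbers, compound 1 being the nearest and sitting well above it.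

Compound 3 `CN1CCC(CNc2ccc3[nH]nc(-c4cnn(C)c4)c3c2)CC1` is not yet measured. Relative to compound 2 the change is (1-methylpiperidin-4-yl)methyl in place of phenyl on a nitrogen on an aromatic ring. Among the compounds with values here, the only step that bears on this, a 15-fold lower number from compound 1 to compound 2 (1.19 log units; beyond the scatter), shows that placing a group on that nitrogen in place of hydrogen lowers the number strongly; whether a six-membered non-aromatic ring on a one-carbon link does the same as a phenyl is untested. The step is expected to be a 2.6-fold higher number from compound 2 to compound 3 (0.41 log units; beyond the scatter), that is, a number somewhat higher than that of compound 2 yet still well below that of compound 1. Compound 3 is thus estimated at 1500 nM in this assay, with a range from 300 nM to 7000 nM.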

Compound 3, half-maximal inhibitory concentration: 1850000 nM
Estimate against measurement, compound 3: 1200-fold (3.09 log units) below; measured number outside the range, above it.
By their numbers in this assay, from the lowest: compound 2; then compound 1; then compound 3.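

In this assay, a group on this nitrogen on an aromatic ring does not lower the number as such: (1-methylpiperidin-4-yl)methyl in place of phenyl gives a 3200-fold higher number from compound 2 to compound 3 (3.50 log units; beyond the scatter), and the same group in place of hydrogen gives a 210-fold higher number from compound 1 to compound 3 (2.32 log units; beyond the scatter). Phenyl and (1-methylpiperidin-4-yl)methyl therefore move the number in opposite directions from the hydrogen of compound 1, which places the unsubstituted nitrogen between the two substituted compounds and makes the outcome at this position depend on the group carried there, at least across these three compounds. No measurement here accounts for the large rise seen with the (1-methylpiperidin-4-yl)methyl group.

Compound 3 differs from compound 2 in its ring, its one-carbon link and its extra nitrogen all at once, so the compounds shown do not say which of these parts goes with the higher number. From the compounds shown here alone, it remains open whether a benzyl group, which keeps the aromatic carbon ring on a one-carbon link, or a cyclohexylmethyl group, which keeps the non-aromatic ring without a nitrogen in it, would give a number nearer that of compound 2 or that of compound 3.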